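The compounds below may be only part of what the source reports. "The series", "measured", "known", "first", "only" and "open" are said of these compounds alone.

Measured so far in a functional assay on HepG2 cells (Homo sapiens) for antiproliferative activity, read by MTT assay, with a stated time of 72 h; on this read-out higher numbers stand for weaker inhibition and lower numbers for stronger inhibition:
Compound 1 `O=C1O/C(=C\Cn2cnc3c(F)nc(F)c(Cl)c32)C(OCc2ccccc2)=C1OCc1ccccc1`: > 100000 nM
Compound 2 `O=C1NC(O)(CCn2cnc3cc[nH]c3c2=O)C(OCc2ccccc2)=C1OCc1ccccc1`: > 100000 nM

Both entries are limits of the assay and not numbers, so neither compound has a measured potency. Compound 1 gives > 100000 nM in this assay, and this is a limit. Compound 2 gives > 100000 nM, which is likewise a limit. The two therefore stand together at the limit of > 100000 nM in this assay, at which 2 of the 2 values shown sit, and no order can be drawn between them.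

Compound 3 `O=C1O/C(=C\Cn2cnc3c(Cl)c(F)nc(F)c32)C(OCc2ccccc2)=C1OCc1ccccc1` has not yet been measured in this assay. It has the same atoms as compound 1, joined differently. The change is a group of 12 heavy atoms (6 carbon, 3 nitrogen, 2 fluorine, 1 chlorine; one five-membered aromatic ring with 2 hetero atoms, one six-membered aromatic ring with 1 hetero atom) in place of a group of 12 heavy atoms (6 carbon, 3 nitrogen, 2 fluorine, 1 chlorine; one five-membered aromatic ring with 2 hetero atoms, one six-membered aromatic ring with 1 hetero atom), on a saturated chain carbon bound to a double-bonded chain carbon, and the rest of the molecule stays as it is.

Within the data shown here, no measured step shows what such a change does. The expectation therefore rests only on compound 1 with its limit of > 100000 nM. The estimated change, a number no higher from compound 1 to compound 3 (the limit leaves the size open), is expected to be none beyond the scatter, with no direction favoured. Compound 3 is expected at about 100000 nM, with an estimated range from 30000 nM to 300000 nM.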

Compound 3, half-maximal inhibitory concentration: > 100000 nM
Compound 3: only a limit was reported (the forecaster's own chance of this, stated with the estimate: 70%); the middle value lies on the limit itself.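

In this assay compound 3 gives > 100000 nM as a limit and not a number. Among these compounds, compound 1 also stands at a limit, so no step from compound 1 to compound 3 can be read: the limit of > 100000 nM in this assay, at which 3 of the 3 values shown sit. The compounds shown leave open whether any change to the shared core would give a measurable value in this assay.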